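Replacing a hydroxyethyl chain with a chlorophenyl ring

The compounds below may be only part of what the source reports. "The series", "measured", "known", "first", "only" and "open" are said of these compounds alone.

Measured compounds:
compound 1 `Cc1[nH]c2ccccc2c1-c1ccnc(NCCO)n1`, 11000 nM
compound 2 `COc1ccc2c(c1)/C(=N/NC(=O)c1cc(Br)ccc1O)C(=O)N2`, 9400 nM

In an assay on isolated protein for inhibition of interferon-induced, double-stranded RNA-activated protein kinase (Homo sapiens), read by luminescence, with a stated time of 10 min (a lower number here means a stronger inhibitor, a higher number a weaker inhibitor), compound 1 gives 11000 nM, the highest of the two numbers recorded, while compound 2 gives 9400 nM, a gap that lies within the scatter, so the two cannot be ordered. Compound 3 `Cc1[nH]c2ccccc2c1-c1ccnc(Nc2cccc(Cl)c2)n1` has not yet been measured. It differs from compound 1 in one place: 3-chlorophenyl in place of 2-hydroxyethyl on a nitrogen on an aromatic ring. Going by the values given here, no pair of measured compounds shares this change, so its effect in this assay is not known from the data at hand; it has to be judged on the change alone. Compound 3 is expected to give a lower number than compound 1, a step of a 5.5-fold lower number from compound 1 to compound 3 (0.74 log units; beyond the scatter), which is beyond the scatter. The estimate for compound 3 in this assay is 2000 nM, with a range from 400 nM to 10000 nM.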

Compound 3, half-maximal inhibitory concentration: 300 nM
Compound 3: middle estimate off by 6.7-fold (0.82 log units), on the high side; the whole stated range lies above it.
By their numbers in this assay, from the lowest: compound 3; then compounds 2 and 1 (each within the scatter of the next).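

In this assay, the group on the nitrogen on an aromatic ring proves decisive for the number: 3-chlorophenyl in place of 2-hydroxyethyl gives a 37-fold lower number from compound 1 to compound 3 (1.56 log units; beyond the scatter), a large step. The change replaces a chain with no ring, carrying one hydrogen-bond donor and one acceptor, with a six-membered aromatic ring bearing chlorine and carrying neither, so several features differ at once. Nothing available explains the lower number or assigns it to any one of these differences.

From the compounds shown here alone, whether the step belongs to the aromatic ring itself or to its chlorine stays open, as does how a plain phenyl or a cyclohexyl ring would read at this nitrogen. Compound 2 differs from compound 3 in more than one place, so it cannot settle this.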